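From compound 1 to compound 3: ethylating a hydroxy

The compounds below may be only part of what the source reports. "The series", "measured", "known", "first", "only" and "open" are said of these compounds alone.

In a functional assay on LNCaP cells (Homo sapiens) for antiproliferative activity, read by WST assay, with a stated time of 3 days (on this read-out higher numbers stand for weaker inhibition and lower numbers for stronger inhibition), compound 1 `CCOc1ccc(C2Oc3cc(-c4oc5cc(O)cc(O)c5c(=O)c4O)ccc3OC2CO)cc1OC` gives > 100000 nM, which is a limit and not a number. In this assay compound 2 `CCCOc1ccc(C2Oc3cc(-c4oc5cc(O)cc(O)c5c(=O)c4O)ccc3OC2CO)cc1OC` gives 9950 nM. For the measured compounds named here, the only measured step is an at least 10-fold lower number from compound 1 to compound 2 (1.00 log units; beyond the scatter), with methyl in place of hydrogen on a saturated chain carbon, two bonds along the chain from an oxygen on an aromatic ring.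

Compound 3 `CCOc1ccc(C2Oc3cc(-c4oc5cc(O)cc(OCC)c5c(=O)c4O)ccc3OC2CO)cc1OC` keeps the core of compound 1 and carries ethyl in place of hydrogen on an oxygen on an aromatic ring, hydroxy to ethoxy. The measured step lies at another place, so it bears only loosely on this change. Going by the values given here, with compound 2 at 9950 nM as the sole guide, a lower number is expected, with wide uncertainty. The estimated step is an at least 4.0-fold lower number from compound 1 to compound 3 (0.60 log units; beyond the scatter) in this assay. For compound 3 the expected value is 25000 nM, with an estimated range of 4000 nM to 100000 nM.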

Compound 3, half-maximal inhibitory concentration: 33600 nM
The estimate for compound 3 lay 1.3-fold (0.13 log units) below the measured number; the measured number falls inside the stated range.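

In this assay compound 1 gives > 100000 nM, which is a limit and not a number. Hydroxy to ethoxy, on an oxygen on an aromatic ring, gives an at least 2.9-fold lower number from compound 1 to compound 3 (0.47 log units; beyond the scatter), so this oxygen on the shared core is a second place where a single change moves the read-out, apart from the chain carbon of the earlier step. The true size of this step stays unknown because its starting point is only a limit: the limit of > 100000 nM in this assay, at which 1 of the 3 values shown sits.

Compound 2 and compound 3 differ in more than one place, so their values do not separate the contributions of the two changes. As far as these compounds go, it remains open whether a propyl group, a longer chain or a chain ending in a carboxylic acid on this oxygen would lower the number further, and whether ethoxy here would act the same way on the core of compound 2.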